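This account rests on a few compounds, and the source may have more. Where it says the series, first, only, none or still open, it means among the compounds named here.

The compounds measured in a functional assay on PC-3 cells (Homo sapiens) for antiproliferative activity, read by MTT assay, with a stated time of 72 h; on this read-out lower numbers stand for stronger inhibition and higher numbers for weaker inhibition:

Compound 1, `O=C(N/N=C/c1cccn1CCCN1CCCCC1)Nc1ccc(Oc2ccnc3[nH]ccc23)c(F)c1`: 2840 nM
Compound 2, `CN1CCN(CCCn2cccc2/C=N/NC(=O)Nc2ccc(Oc3ccnc4[nH]ccc34)c(F)c2)CC1`: 2190 nM
Compound 3, `O=C(N/N=C/c1cccn1CCCN1CCCCC1)Nc1ccc(Oc2ccnc3[nH]ccc23)cc1`: 3580 nM

All three share one core and differ at two places. Compound 2 is obtained from compound 1 by 4-methylpiperazin-1-yl in place of piperidin-1-yl on a saturated chain carbon, three bonds along the chain from an aromatic nitrogen, and in this assay this gives a 1.3-fold lower number from compound 1 to compound 2 (0.11 log units; within the scatter). Compound 3 is obtained from compound 1 by hydrogen in place of fluoro on an aromatic carbon, and here the result is a 1.3-fold higher number from compound 1 to compound 3 (0.10 log units; within the scatter). Going by the values given here, of the three values, the one for compound 3 is the highest, but its gaps to compound 1 and to compound 2 both lie within the scatter, so no order among the three can be read from them.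

Compound 4, `CN1CCN(CCCn2cccc2/C=N/NC(=O)Nc2ccc(Oc3ccnc4[nH]ccc34)cc2)CC1`, has not yet been measured in this assay. It differs from compound 3 by 4-methylpiperazin-1-yl in place of piperidin-1-yl on a saturated chain carbon, three bonds along the chain from an aromatic nitrogen. This is the same change that leads from compound 1 to compound 2, made at the same place word for word, now on the core of compound 3 that carries hydrogen where compound 1 carries fluoro.

Among the compounds with values here, the only guide is the single earlier step, which stayed within the scatter. Compound 4 is therefore expected to give about 2750 nM, most likely between 1400 nM and 5500 nM. Compound 4 is estimated to show a step of a 1.3-fold lower number from compound 3 to compound 4 (0.11 log units; within the scatter), because the same change once gave a 1.3-fold lower number from compound 1 to compound 2 (0.11 log units; within the scatter).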

Compound 4, half-maximal inhibitory concentration: 3740 nM
For compound 4 the middle estimate is 1.4-fold (0.13 log units) below the measured one; low and high end bracket the measured number.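

In this assay, 4-methylpiperazin-1-yl in place of piperidin-1-yl on the core without fluoro gives a 1.0-fold higher number from compound 3 to compound 4 (0.02 log units; within the scatter), and this step does not differ from the one seen on the fluoro core: the same change on two cores in this assay, a 1.3-fold lower number (0.11 log units; within the scatter) from compound 1 to compound 2 and a 1.0-fold higher number (0.02 log units; within the scatter) from compound 3 to compound 4, 1.4-fold (0.13 log units) apart, within the scatter of two such steps. Hydrogen in place of fluoro, read on the 4-methylpiperazin-1-yl side, gives a 1.7-fold higher number from compound 2 to compound 4 (0.23 log units; within the scatter), and this step likewise does not differ from its partner: the same change on two cores in this assay, a 1.3-fold higher number (0.10 log units; within the scatter) from compound 1 to compound 3 and a 1.7-fold higher number (0.23 log units; within the scatter) from compound 2 to compound 4, 1.4-fold (0.13 log units) apart, within the scatter of two such steps. Going by these compounds alone, each exchange thus carries from one core to the other without a readable difference, but every step here lies within the scatter, so this agreement shows only that neither exchange gives a readable step on these two cores, not that a step of real size would carry over in the same way.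

The compounds shown leave open whether another amine at the end of the chain, such as morpholin-4-yl or dimethylamino, or a chain shorter or longer than the 3-(piperidin-1-yl)propyl one, would give a step beyond the scatter. They also leave open whether chloro or methoxy in place of fluoro would do so, and whether such a step would then hold from one core to the other.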